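Methyl for Trifluoromethyl: An Estimate for Compound 4

A few compounds are considered here, and "the series" means these few. Any claim that something is new, unique, unknown or untested is made for them only; others in the source may bear on it.

Measured compounds:
compound 1 `CC(C)Cc1ccc(C(C)c2nnc3n2N=C(c2ccc(OC(F)(F)F)cc2)CS3)cc1` — 1100 nM
compound 2 `CC(c1ccc(-c2ccccc2)c(F)c1)c1nnc2n1N=C(c1ccc([N+](=O)[O-])cc1)CS2` — 7800 nM
compound 3 `CC(c1ccc(-c2ccccc2)c(F)c1)c1nnc2n1N=C(c1ccc(F)cc1)CS2` — 8100 nM

In a functional assay on MCF7 cells (Homo sapiens) for inhibition, read by sulforhodamine B assay, with a stated time of 72 h (a higher number here means a weaker inhibitor, a lower number a stronger inhibitor), compound 1 stands lowest of the three numbers, and its gaps to compound 2 and compound 3 lie beyond the scatter. Going by the values given here, the only single-place step among the measured compounds is a 1.0-fold higher number from compound 2 to compound 3 (0.02 log units; within the scatter), a swap on a different part of the shared core from the one now in question. Compound 4 `COc1ccc(C2=Nn3c(nnc3C(C)c3ccc(CC(C)C)cc3)SC2)cc1` differs from compound 1 by methyl in place of trifluoromethyl on an oxygen on an aromatic ring. Among the compounds with values here, no measured step bears on this change, so compound 4 is expected to give a number close to that of compound 1, with no step beyond the scatter in either direction: the expected step is a 1.2-fold higher number from compound 1 to compound 4 (0.07 log units; within the scatter). The estimate for compound 4 is 1300 nM, between 500 nM and 3500 nM.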

Compound 4, half-maximal inhibitory concentration: 5200 nM
For compound 4 the middle estimate is 4.0-fold (0.60 log units) below the measured one; the measured number lies above the stated range.
By their numbers in this assay, from the lowest: compound 1; then compounds 4, 2 and 3 (each within the scatter of the next).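

In this assay the change from trifluoromethoxy to methoxy gives a 4.7-fold higher number from compound 1 to compound 4 (0.67 log units; beyond the scatter) and so moves the number beyond the scatter. Going by these compounds alone, this shows that the group on this oxygen matters in this pair, which the one earlier step, made on a different part of the shared core, could not show. The data shown offer no measurement that accounts for this step.

From the compounds shown here alone, whether ethyl or another longer chain on this oxygen, or a hydroxyl in place of the whole methoxy, would stand nearer compound 1 or compound 4 remains open. Also open, going by these compounds, is whether the same change would give a similar step on the scaffold of compound 2 and compound 3.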